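The source may report more compounds than this note shows. Statements on the series, on what has been measured and on what is new or still open speak of the compounds shown alone.

Measured in an ADME assay on TZM cells (Homo sapiens) for cytotoxicity, read by XTT assay, with a stated time of 4 days; on this read-out lower numbers stand for higher toxicity in this test and higher numbers for lower toxicity in this test:
- compound 1 `Cc1cc(CCC#N)cc(C)c1Oc1cc(Nc2ccc(C#N)cc2)c(N)cc1C(=O)O`: 14300 nM
- compound 2 `CNC(=O)c1cc2ncn(-c3ccc(C#N)cc3)c2cc1Oc1c(C)cc(/C=C/C#N)cc1C`: > 890000 nM, a limit

Within the data shown here, compound 1 holds the only actual number in this assay. The reading for compound 2, > 890000 nM, is a limit and not a number.

Compound 3 `CNC(=O)c1cc(N)c(Nc2ccc(C#N)cc2)cc1Oc1c(C)cc(CCC#N)cc1C` has not yet been measured. It departs from compound 1 by one change, methylamino in place of hydroxy on a carbonyl carbon, or carboxy to methylcarbamoyl. Among the measured compounds shown here, no measured step shows what this change does, so no shift beyond the usual scatter is expected. The estimated step is a 1.4-fold higher number from compound 1 to compound 3 (0.15 log units; within the scatter). Compound 3 is expected at 20000 nM, within an estimated range of 5000 nM to 120000 nM.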

Compound 3, half-maximal cytotoxic concentration: > 9100 nM
Compound 3: only a limit was reported; the forecaster's own chance of this, stated with the estimate: 25%; the middle value does not contradict the limit.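

Compound 3 gives > 9100 nM, which is a limit and not a number, and the step from compound 1 to compound 3 cannot be read. The compounds shown leave open whether methylamino in place of hydroxy on a carbonyl carbon shifts the reading at all.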